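A few compounds are considered here, and "the series" means these few. Any claim that something is new, unique, unknown or untested is made for them only; others in the source may bear on it.

Working notes on the series. In an assay on Sf9 cells for inhibition of mitogen-activated protein kinase kinase kinase 20 (Homo sapiens), read by ADP-Glo, with a stated time of 30 min (on this read-out higher numbers stand for weaker inhibition and lower numbers for stronger inhibition), compound 1 `COc1n[nH]c2ncc(C#Cc3c(F)ccc(NS(=O)(=O)c4cccc(Cl)c4)c3F)cc12` gives 14.7 nM. Compound 2 `COc1n[nH]c2ncc(-c3ncc(-c4c(F)ccc(NS(=O)(=O)c5cccc(Cl)c5)c4F)[nH]3)cc12` gives 983 nM in this assay, the highest of the three numbers shown. Compound 3 `COc1n[nH]c2ncc(-c3cn(-c4c(F)ccc(NC(=O)c5cccc(Cl)c5)c4F)nn3)cc12` gives 54.3 nM in this assay and stands second highest of the three, nearer to compound 1 than to compound 2; both of its gaps lie beyond the scatter.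

Compound 4 `COc1cccc(S(=O)(=O)Nc2ccc(F)c(-n3cc(-c4cnc5[nH]nc(OC)c5c4)nn3)c2F)c1` is not yet measured in this assay. It differs from compound 3 in one place: (3-methoxyphenyl)sulfonyl in place of (3-chlorophenyl)carbonyl on a nitrogen on an aromatic ring. Within the data shown here, no measured pair isolates this change, so its size has to be expected rather than read off. Compound 1 and compound 2, each carrying a sulfonyl on the same nitrogen, bracket compound 3 with its carbonyl, so the direction of the step is open; a step from compound 3 to compound 4 of a 1.6-fold lower number from compound 3 to compound 4 (0.19 log units; within the scatter) is expected, with no strong direction beyond the scatter. On that basis compound 4 is estimated at 35 nM in this assay, within a range from 9 nM to 140 nM.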

Compound 4, half-maximal inhibitory concentration: 2.3 nM
For compound 4 the middle estimate is 15-fold (1.18 log units) above the measured one; the measured number lies below the stated range.
By their numbers in this assay, from the lowest: compound 4; then compound 1; then compound 3; then compound 2.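

Among these compounds, the pair gives the first direct reading at this position: (3-methoxyphenyl)sulfonyl in place of (3-chlorophenyl)carbonyl on a nitrogen on an aromatic ring gives a 24-fold lower number from compound 3 to compound 4 (1.37 log units; beyond the scatter) in this assay. The position is therefore sensitive to this change, and the change runs towards stronger inhibition by a large margin. No measurement at hand accounts for the size of this step.

The step changes the carbonyl to a sulfonyl and the chlorine to a methoxy at once, so the pair cannot say how much of it belongs to each; a (3-methoxyphenyl)carbonyl on the same nitrogen would begin to separate them. On these data alone, how an amine or a carboxylic acid would read in place of the methoxy also stays open.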